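Butylsulfanyl to Cyclopentylsulfanyl at the Same Sulfur

A few compounds are considered here, and "the series" means these few. Any claim that something is new, unique, unknown or untested is made for them only; others in the source may bear on it.

Compound 1, `CC1CCN(c2cc(C(F)(F)F)ccc2CNC(=O)C(C)c2ccc(NS(C)(=O)=O)c(F)c2)CC1`, gives 0.9 nM in an assay on CHO cells for antagonist activity at transient receptor potential cation channel subfamily V member 1 (Homo sapiens), read by FLIPR; on this read-out lower numbers stand for stronger inhibition and higher numbers for weaker inhibition.
Compound 2, `CC(C(=O)NCc1ccc(C(F)(F)F)cc1N1CCC(C(F)(F)F)CC1)c1ccc(NS(C)(=O)=O)c(F)c1`, gives 0.4 nM in this assay.
Compound 3, `CCCCSc1cc(C(F)(F)F)ccc1CNC(=O)C(C)c1ccc(NS(C)(=O)=O)c(F)c1`, gives 1.9 nM in this assay.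

Among these three, compound 3 shows the highest number, and so the weakest inhibition: the steps of a 2.1-fold higher number from compound 1 to compound 3 (0.32 log units; beyond the scatter) and a 4.8-fold higher number from compound 2 to compound 3 (0.68 log units; beyond the scatter) are both beyond the scatter, though modest. Compound 4, `CC(C(=O)NCc1ccc(C(F)(F)F)cc1SC1CCCC1)c1ccc(NS(C)(=O)=O)c(F)c1`, differs from compound 3 in a single place: cyclopentyl in place of butyl on a sulfur.

For the measured compounds named here, none of the measured steps tests this exact exchange. The step of a 2.3-fold lower number from compound 1 to compound 2 (0.35 log units; beyond the scatter) concerns a substituent on a saturated ring carbon in another part of the molecule, and the two steps into compound 3 swap the entire group on the aromatic carbon rather than altering what sits on the sulfur. What they do show is that changes at this position have moved the number only modestly, in either direction. Going by the values given here, with no direct precedent, the expectation is for a change within the scatter, leaning neither way strongly. The estimate for compound 4 in this assay is 1.6 nM, with a range from 0.5 nM to 5 nM. This corresponds to an expected step of a 1.2-fold lower number from compound 3 to compound 4 (0.07 log units; within the scatter).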

Compound 4, inhibition constant: 0.3 nM
Compound 4: middle estimate off by 5.3-fold (0.73 log units), on the high side, outside the stated range (below it).
By their numbers in this assay, from the lowest: compounds 4 and 2 (each within the scatter of the next); then compound 1; then compound 3.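

For the compounds shown here, although the earlier steps changed the whole group on the aromatic carbon, this one changes only what sits on the sulfur, and cyclopentyl in place of butyl gives a 6.3-fold lower number from compound 3 to compound 4 (0.80 log units; beyond the scatter) in this assay, the largest step yet seen in this set. A sulfur-linked group can therefore match the better piperidine: swapping 4-(trifluoromethyl)piperidin-1-yl for cyclopentylsulfanyl gives a 1.3-fold lower number from compound 2 to compound 4 (0.12 log units; within the scatter), while swapping 4-methylpiperidin-1-yl for it gives a 3.0-fold lower number from compound 1 to compound 4 (0.48 log units; beyond the scatter). Nothing available explains why the ring and the chain differ.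

With only butyl and cyclopentyl on the sulfur, the compounds shown cannot separate the effect of having a ring from that of having one more carbon. A pentyl chain, or a cyclobutyl or cyclohexyl ring, on the same sulfur would help to tell these apart.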